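Reshuffling a hydroxyl on a diaryl pyridine scaffold

The source may report more compounds than this note shows. Statements on the series, on what has been measured and on what is new or still open speak of the compounds shown alone.

In a functional assay on DU-145 cells (Homo sapiens) for inhibition (on this read-out lower numbers stand for stronger inhibition and higher numbers for weaker inhibition), compound 3 `Oc1ccc(-c2cc(-c3cccc(OC(F)(F)F)c3)cc(-c3cccc(O)c3)n2)cc1` gives 5670 nM, the lowest of the two numbers obtained so far. Its nearest neighbour is compound 1 `Oc1ccc(-c2cc(-c3cccc(F)c3)cc(-c3ccc(O)cc3)n2)cc1`, which in this assay gives 9290 nM; the gap between these two values lies within the scatter, so no order can be read from them. Compound 2 `Oc1ccc(-c2cc(-c3cccc(C(F)(F)F)c3)cc(-c3ccc(O)cc3)n2)cc1` reaches only the limit of this assay, > 50000 nM. Among the compounds with values here, the one step measured in one place, an at least 5.3-fold higher number from compound 1 to compound 2 (0.73 log units; beyond the scatter), concerns an exchange on the pendant aryl ring and not the hydroxyphenyl arms, so it does not bear on the change considered here.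

Compound 4 `Oc1ccc(-c2cc(-c3cccc(OC(F)(F)F)c3)cc(-c3ccc(O)cc3)n2)cc1` differs from compound 3 in a single place: 4-hydroxyphenyl in place of 3-hydroxyphenyl on an aromatic carbon. Within the data shown here, no measured pair isolates this exchange. Compounds 1 and 3 carry both arrangements of the hydroxyphenyl arm and sit within the scatter of each other, but they also differ in the pendant substituent, so their two values alone give no clean reading. With nothing shown to drive a shift, the step is expected to be a 1.2-fold higher number from compound 3 to compound 4 (0.09 log units; within the scatter), that is, none beyond the scatter. For compound 4 the estimate in this assay is 7000 nM, with a range from 2500 nM to 20000 nM.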

Compound 4, half-maximal inhibitory concentration: > 50000 nM
Compound 4: no number, only a limit; the forecaster's own chance of this, stated with the estimate: 10%; middle value at least 7.1-fold (0.85 log units) away from the limit.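

Moving the hydroxyl on this arm matters in this assay: 4-hydroxyphenyl in place of 3-hydroxyphenyl, on the aromatic carbon next to the ring nitrogen, gives an at least 8.8-fold higher number from compound 3 to compound 4 (0.94 log units; beyond the scatter). Within the data shown here, no earlier pair isolated this exchange, and it now shows a step beyond the scatter. Among the compounds carrying two 4-hydroxyphenyl arms, trifluoromethoxy in place of fluoro on the pendant ring gives an at least 5.3-fold higher number from compound 1 to compound 4 (0.73 log units; beyond the scatter), which leaves compound 1 as the only one of them with a number rather than a limit. The step between compound 2 and compound 4 cannot be read, as both values are limits of the assay: the limit of > 50000 nM in this assay, at which 2 of the 4 values shown sit.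

As far as these compounds go, how far beyond that limit compound 2 and compound 4 lie stays open, as does whether a 3-hydroxyphenyl arm would give a number with fluoro or trifluoromethyl on the pendant ring. The compounds shown also do not tell whether an amine or a carboxylic acid in place of the hydroxyl on this arm would keep a number in this assay.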